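Replacing a Methoxymethyl Group with a Dihydroxypropyl Amide

The compounds below may be only part of what the source reports. "The series", "measured", "known", "first", "only" and "open" are said of these compounds alone.

Measured so far in a functional assay on LNCaP cells (Homo sapiens) for antiproliferative activity; a higher number here means a weaker inhibitor, a lower number a stronger inhibitor:
- compound 1, `Cn1ncc(Cl)c1-c1cc(C(=O)N[C@@H]2CN[C@H](CCN3CCC(O)CC3)C[C@H]2c2ccc(Cl)c(Cl)c2)oc1Cl`: 1140 nM
- compound 2, `C=CC[C@@H]1C[C@@H](c2ccc(Cl)c(Cl)c2)[C@H](NC(=O)c2cc(-c3c(Cl)cnn3C)c(Cl)o2)CN1`: 160 nM
- compound 3, `COCC[C@@H]1C[C@@H](c2ccc(Cl)c(Cl)c2)[C@H](NC(=O)c2cc(-c3c(Cl)cnn3C)c(Cl)o2)CN1`: 250 nM

All three share one core and differ only in the side chain on a saturated chain carbon bound to a saturated ring carbon. Compound 3 gives the second highest of the three numbers: its nearest neighbour is compound 2, where a 1.6-fold higher number from compound 2 to compound 3 (0.19 log units; within the scatter), a gap inside the usual scatter, so the two cannot be ranked. Its furthest neighbour is compound 1, where a 4.6-fold lower number from compound 1 to compound 3 (0.66 log units; beyond the scatter).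

Compound 4, `Cn1ncc(Cl)c1-c1cc(C(=O)N[C@@H]2CN[C@H](CC(=O)NCC(O)CO)C[C@H]2c2ccc(Cl)c(Cl)c2)oc1Cl`, is not yet measured. It differs from compound 3 in one place: (2,3-dihydroxypropyl)carbamoyl in place of methoxymethyl on a saturated chain carbon bound to a saturated ring carbon. The group that enters is the larger of the two, as the counts show.

Within the data shown here, the steps that bear on this change are a 7.1-fold lower number from compound 1 to compound 2 (0.85 log units; beyond the scatter) and a 4.6-fold lower number from compound 1 to compound 3 (0.66 log units; beyond the scatter): in both, trading a larger side chain for a small one gave a clearly lower number in this assay. Compound 4 moves the other way, from a small side chain to a larger one, so a higher number is expected for compound 4 in this assay, roughly a 3.2-fold higher number from compound 3 to compound 4 (0.51 log units; beyond the scatter). Compound 4 is thus estimated at 800 nM, with a range from 300 nM to 2500 nM.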

Compound 4, half-maximal inhibitory concentration: 660 nM
Beside the measured number, compound 4's estimate is 1.2-fold (0.08 log units) above it, and the stated range covers the measured number.
By their numbers in this assay, from the lowest: compounds 2 and 3 (each within the scatter of the next); then compounds 4 and 1 (each within the scatter of the next).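

Compound 4 brings a second large side chain into the comparison, this one without a ring. In this assay it is also a weaker inhibitor than the small side chains, showing a 2.6-fold higher number from compound 3 to compound 4 (0.42 log units; beyond the scatter) against the methoxymethyl group and a 4.1-fold higher number from compound 2 to compound 4 (0.62 log units; beyond the scatter) against the vinyl group. So across these four compounds, the higher numbers go with the two larger side chains, and neither small side chain goes against this. The remaining step, a 1.7-fold lower number from compound 1 to compound 4 (0.24 log units; within the scatter), leaves the two large side chains unranked, even though only one of them holds a ring, so a ring in this side chain is not needed for the higher number.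

On these data alone, what a carboxylic acid, a plain methyl amide or a simple primary amine would give at this saturated chain carbon remains open, and these groups could help separate the effect of size from that of the amide and the hydroxyl groups. No measurement shown gives a reason for any of these differences.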